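Changing Chloro to Trifluoromethyl on Two Related Cores

A few compounds are considered here, and "the series" means these few. Any claim that something is new, unique, unknown or untested is made for them only; others in the source may bear on it.

Three compounds have been measured in a functional assay on GLC82 cells (Homo sapiens) for cytotoxicity, read by MTT assay, with a stated time of 72 h; on this read-out higher numbers stand for weaker inhibition and lower numbers for stronger inhibition:

compound 1 `COc1cc2ncnc(NNC(=S)NC(=O)c3ccc(Cl)cc3)c2cc1OC`: 9620 nM
compound 2 `O=C(NC(=S)NNc1ncnc2ccccc12)c1ccc(Cl)cc1`: 6680 nM
compound 3 `COc1cc2ncnc(NNC(=S)NC(=O)c3ccc(C(F)(F)F)cc3)c2cc1OC`: 16500 nM

Compound 1 and compound 2 carry the same thiourea-linked benzoyl part on different cores; the difference between the two cores is not broken down here. Compound 3 differs from compound 1 by trifluoromethyl in place of chloro on an aromatic carbon. That change gave a 1.7-fold higher number from compound 1 to compound 3 (0.23 log units; within the scatter).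

Compound 4 `O=C(NC(=S)NNc1ncnc2ccccc12)c1ccc(C(F)(F)F)cc1` has not yet been measured. It differs from compound 2 by trifluoromethyl in place of chloro on an aromatic carbon, the same change at the same place. The step from compound 2 to compound 4 is expected to be a 1.6-fold higher number from compound 2 to compound 4 (0.22 log units; within the scatter) because the same change gave a 1.7-fold higher number from compound 1 to compound 3 (0.23 log units; within the scatter). On that basis compound 4 is estimated at 11000 nM in this assay, most likely between 5500 nM and 22000 nM.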

Compound 4, half-maximal inhibitory concentration: 12200 nM
For compound 4 the middle estimate is 1.1-fold (0.04 log units) below the measured one; measured number inside the range.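

In this assay, trifluoromethyl in place of chloro gave a 1.8-fold higher number from compound 2 to compound 4 (0.26 log units; within the scatter). The step is much the same size on both cores: the same change on two cores in this assay, a 1.7-fold higher number (0.23 log units; within the scatter) from compound 1 to compound 3 and a 1.8-fold higher number (0.26 log units; within the scatter) from compound 2 to compound 4, 1.1-fold (0.03 log units) apart, within the scatter of two such steps

This shows that, in this assay, the change carried over from one core to the other without a detectable difference. It does not show that trifluoromethyl and chloro truly differ here, as each step on its own lies within the scatter, and two cores say nothing about any other core.

Only chloro and trifluoromethyl appear at this place on the benzoyl ring, leaving open what an amine, a nitrile or a carboxylic acid would do there. As far as these compounds go, whether the two steps would also match on other cell lines remains open too.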